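A few compounds are considered here, and "the series" means these few. Any claim that something is new, unique, unknown or untested is made for them only; others in the source may bear on it.

Series notes. Compound 1 `CSc1nc(-c2cccs2)c(C#N)c(=O)n1C`, compound 3 `Cn1c(NN)nc(-c2cccs2)c(C#N)c1=O` and compound 2 `COc1cccc(-c2nc(NN)n(C)c(=O)c2C#N)c1OC` have been run in a functional assay, with a stated time of 10 min; on this read-out lower numbers stand for stronger inhibition and higher numbers for weaker inhibition. Compound 1 gives 72 ug/mL, compound 3 gives 53 ug/mL and compound 2 gives 36 ug/mL; the difference between the core of compound 2 and the core of compound 3 is not broken down here. Among the compounds with values here, the one single-point change measured so far is methylsulfanyl in place of aminoamino on an aromatic carbon, which gave a 1.4-fold higher number from compound 3 to compound 1 (0.13 log units; within the scatter). Compound 4 `COc1cccc(-c2nc(SC)n(C)c(=O)c2C#N)c1OC` has not yet been measured in this assay. It arises from compound 2 by methylsulfanyl in place of aminoamino on an aromatic carbon. Within the data shown here, this is the same kind of change as the one from compound 3 to compound 1, not the same: the place is described as meta to a thiophen-2-yl group in the one case and meta to a large group in the other. For compound 4 a step of about a 1.4-fold higher number from compound 2 to compound 4 (0.14 log units; within the scatter) is expected in this assay, set beside the earlier one, because the same kind of change gave a 1.4-fold higher number from compound 3 to compound 1 (0.13 log units; within the scatter) and compound 2 starts from 36 ug/mL. Compound 4 is therefore estimated at 50 ug/mL, with the expected range running from 25 ug/mL to 100 ug/mL.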

Compound 4, half-maximal inhibitory concentration: 43 ug/mL
The estimate for compound 4 lay 1.2-fold (0.07 log units) above the measured number; the range from low to high includes it.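

In this assay, methylsulfanyl in place of aminoamino on the core of compound 2 gave a 1.2-fold higher number from compound 2 to compound 4 (0.08 log units; within the scatter). Set beside the earlier step, the change reads the same on both cores: the same change on two cores in this assay, a 1.4-fold higher number (0.13 log units; within the scatter) from compound 3 to compound 1 and a 1.2-fold higher number (0.08 log units; within the scatter) from compound 2 to compound 4, 1.1-fold (0.06 log units) apart, within the scatter of two such steps. This shows that the exchange of these two groups carries from one core to the other without a readable difference, but both steps are small enough to lie within the scatter, so the agreement is between two steps that cannot be told from no change, and it does not show that a larger effect would carry over in the same way or that the result extends to cores beyond these two.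

Going by these compounds, it remains open whether another group at this place, such as an amine like dimethylamino or a longer chain like ethylsulfanyl, would move the number beyond the scatter. Also open, on these data alone, is how the series responds to changes elsewhere, for instance a carboxylic acid in place of the cyano group.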